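Working notes: step from compound 3 to compound 4

A few compounds are considered here, and "the series" means these few. Any claim that something is new, unique, unknown or untested is made for them only; others in the source may bear on it.

Compound 3 `CCc1ccc2[nH]c(=O)c(CN(Cc3ccc(O)cc3)Cc3ccc(C(C)(C)C)cc3)cc2c1` stands in a toxicity assay on MDCK cells (Canis lupus familiaris) for cytotoxicity, read by crystal violet staining, with a stated time of 48 h (on this read-out lower numbers stand for higher toxicity in this test and higher numbers for lower toxicity in this test), only as a limit: compound 3 gives > 10000 nM, which is a limit of the assay rather than a number (the limit of > 10000 nM in this assay, at which 1 of the 3 values shown sits). Compound 2 `Cc1ccc2[nH]c(=O)c(CN(Cc3ccc(O)cc3)Cc3ccc(C(C)(C)C)cc3)cc2c1` gives 4900 nM in this assay. Within the data shown here, the single measured step in the set, an at least 2.0-fold higher number from compound 2 to compound 3 (0.30 log units; that floor lies within the scatter), rests on that limit and so cannot be sized beyond the scatter. Compound 1 `Cc1ccc2cc(CN(Cc3ccc(Cl)cc3)Cc3ccc(C(C)C)cc3)c(=O)[nH]c2c1` also reports a limit in this assay, giving > 33000 nM (the limit of > 33000 nM in this assay, at which 1 of the 3 values shown sits). Compound 1 differs from compound 3 in more than one place, so only the two values themselves can be set side by side.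

Compound 4 `CCc1ccc2[nH]c(=O)c(CN(Cc3ccc(C(C)(C)C)cc3)C(C)c3ccc(OC)cc3)cc2c1` carries 1-(4-methoxyphenyl)ethyl in place of 4-hydroxybenzyl on an amine nitrogen. Among the measured compounds shown here, no measured step in this set touches a change on the amine nitrogen; the measured steps concern only the saturated chain carbon bound to an aromatic carbon. No step beyond the scatter can therefore be derived for compound 4, and a reading near that of compound 3 is expected, most probably again a limit. Compound 4 is estimated in this assay at 15000 nM, with a range of 4000 nM to 50000 nM. The estimated step that the limit leaves unreadable from compound 3 to compound 4 is expected to stay within the scatter.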

Compound 4, half-maximal cytotoxic concentration: > 5000 nM
Compound 4: only a limit was reported; the forecaster's own chance of this, stated with the estimate: 60%; the middle value lies beyond the limit too.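

In this assay, among these compounds, compound 3 and compound 4 each report only a limit of the assay, so no step between them can be read. The compounds shown leave open whether 1-(4-methoxyphenyl)ethyl in place of 4-hydroxybenzyl on an amine nitrogen changes this read-out at all, and in which direction.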